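A Flat Series Meets Isopropyl

The source may hold more compounds than are shown below. What is called first, only, known or untested is meant among the compounds shown, and "the series" means these compounds.

In a functional assay on KB-V1 cells (Homo sapiens) for cytotoxicity, read by MTT assay, with a stated time of 72 h (a lower number here means a stronger inhibitor, a higher number a weaker inhibitor), three compounds built on one shared core have been measured. Compound 1 `O=C1Nc2ccccc2/C1=N/NC(=S)Nc1ccccc1` gives 1470 nM, compound 2 `O=C1Nc2ccccc2/C1=N/NC(=S)Nc1ccc(F)cc1` gives 1920 nM and compound 3 `O=C1Nc2ccccc2/C1=N/NC(=S)Nc1ccc(C(F)(F)F)cc1` gives 2100 nM. Compound 3 therefore stands within the scatter of both other compounds. Compound 4 `CC(C)c1ccc(NC(=S)N/N=C2\C(=O)Nc3ccccc32)cc1` has not yet been measured. It differs from compound 3 by isopropyl in place of trifluoromethyl on an aromatic carbon, para to a large group: isopropyl in place of trifluoromethyl on an aromatic carbon. For the measured compounds named here, no measured compound carries isopropyl, so the evidence is indirect. Going by the values given here, the steps that bear on this change are the other replacements on an aromatic carbon: a 1.3-fold higher number from compound 1 to compound 2 (0.12 log units; within the scatter), a 1.4-fold higher number from compound 1 to compound 3 (0.15 log units; within the scatter) and a 1.1-fold higher number from compound 2 to compound 3 (0.04 log units; within the scatter). All three lie within the scatter, so no step beyond it is expected in this assay, in either direction. The expected change is small: a 1.2-fold lower number from compound 3 to compound 4 (0.07 log units; within the scatter). Compound 4 is estimated at 1800 nM, with an expected range from 900 nM to 3500 nM.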

Compound 4, half-maximal inhibitory concentration: 1090 nM
Compound 4: the middle estimate sits 1.7-fold (0.22 log units) above what was measured, and the stated range covers the measured number.
By their numbers in this assay, from the lowest: compounds 4, 1, 2 and 3 (each within the scatter of the next).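

Isopropyl is the first group at this position that brings carbon alone, and in this assay it leaves the series as flat as before: a 1.9-fold lower number from compound 3 to compound 4 (0.28 log units; within the scatter) and a 1.8-fold lower number from compound 2 to compound 4 (0.25 log units; within the scatter) and a 1.3-fold lower number from compound 1 to compound 4 (0.13 log units; within the scatter) all stay within the scatter. Hydrogen, fluoro, trifluoromethyl and isopropyl on this aromatic carbon, para to a large group, thus cannot be told apart in this measurement, and although the exchange of trifluoromethyl for isopropyl is the largest step seen here so far, it cannot be read as a real change. Nothing available accounts for why the four compounds behave alike.

Going by these compounds, it remains open whether an amine, a carboxylic acid or a longer chain at this position would move the number beyond the scatter. On these data alone, all four compounds also share one core, so whether this flatness holds on any other core is unknown.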